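Working notes: step from compound 2 to compound 3

The source may hold more compounds than are shown below. What is called first, only, known or untested is meant among the compounds shown, and "the series" means these compounds.

Measured so far:
- compound 1 `Fc1ccc(CO/N=C2/C(c3c[nH]c4ccccc34)=Nc3ccccc32)cc1` — 20700 nM
- compound 2 `FC(F)(F)c1ccc(CO/N=C2/C(c3c[nH]c4ccccc34)=Nc3ccccc32)cc1` — 24100 nM

In a functional assay on NCI-H460 cells (Homo sapiens) for cytotoxicity, read by MTT assay, with a stated time of 2 days (on this read-out lower numbers stand for stronger inhibition and higher numbers for weaker inhibition), compound 2 gives 24100 nM, and the step from compound 1 to compound 2 was a 1.2-fold higher number from compound 1 to compound 2 (0.07 log units; within the scatter), so the two numbers are indistinguishable. Compound 3 `Fc1ccc(CO/N=C2/C(c3c[nH]c4ccccc34)=Nc3ccccc32)c(Cl)c1` differs from compound 2 by 2-chloro-4-fluorophenyl in place of 4-(trifluoromethyl)phenyl on a saturated chain carbon bound to an oxygen on an unsaturated carbon. Among the measured compounds shown here, the only measured step concerns this same aryl group and lay within the scatter; nothing measured covers the entering chloro-fluoro pattern. The expected step is therefore a 1.1-fold lower number from compound 2 to compound 3 (0.04 log units; within the scatter), no change beyond the scatter. Compound 3 is estimated at 22000 nM, range 10000 nM to 50000 nM.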

Compound 3, half-maximal inhibitory concentration: 21900 nM
Beside the measured number, compound 3's estimate is 1.0-fold (0.00 log units) above it; low and high end bracket the measured number.
By their numbers in this assay, from the lowest: compounds 1, 3 and 2 (each within the scatter of the next).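

In this assay, 2-chloro-4-fluorophenyl in place of 4-(trifluoromethyl)phenyl gives a 1.1-fold lower number from compound 2 to compound 3 (0.04 log units; within the scatter) and chloro in place of hydrogen on an aromatic carbon gives a 1.1-fold higher number from compound 1 to compound 3 (0.02 log units; within the scatter) and both steps lie within the scatter. The series now shows that adding chloro to the aryl group, and not only exchanging fluoro for trifluoromethyl, leaves the number unresolved at this position. Nothing available accounts for this result. Still open, from the compounds shown here alone, is whether an amine or a carboxylic acid on this aryl group, or a longer chain at this position, would give a step beyond the scatter.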